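Series notes: benzylamine aryl variations on the shared core

The compounds below may be only part of what the source reports. "The series", "measured", "known", "first", "only" and "open" are said of these compounds alone.

Compound 2 `Cc1cc(Nc2nc(NCc3ccccc3Br)nc3[nH]ncc23)n[nH]1` gives 3990 nM in a functional assay on MDA-MB-231 cells (Homo sapiens) for inhibition, read by MTT assay, with a stated time of 5 days (on this read-out lower numbers stand for stronger inhibition and higher numbers for weaker inhibition), the lowest number of the three measured. Compound 3 `Cc1cc(Nc2nc(NCc3ccc(Cl)cc3)nc3[nH]ncc23)n[nH]1` gives 7500 nM and sits within the scatter of compound 2; compound 1 `Cc1cc(Nc2nc(NCc3ccccc3F)nc3[nH]ncc23)n[nH]1` gives 9850 nM, beyond the scatter. The step to compound 4 `Cc1cc(Nc2nc(NCc3ccc(F)cc3F)nc3[nH]ncc23)n[nH]1` is 2,4-difluorophenyl in place of 2-bromophenyl on a saturated chain carbon bound to a nitrogen on an aromatic ring. Among the compounds with values here, the relevant measured step is a 2.5-fold lower number from compound 1 to compound 2 (0.39 log units; beyond the scatter), so removing bromo in favour of fluoro on the aromatic carbon, as in compound 4, is expected to raise the number again, while the second fluoro of the 2,4-difluorophenyl has no direct precedent; compound 3 shows a 4-halogen alone changes little, a 1.9-fold higher number from compound 2 to compound 3 (0.27 log units; within the scatter). A modest step upward is therefore expected, a 1.8-fold higher number from compound 2 to compound 4 (0.24 log units; within the scatter), giving compound 4 an estimated 7000 nM with a range of 3500 nM to 14000 nM.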

Compound 4, half-maximal inhibitory concentration: 2670 nM
Beside the measured number, compound 4's estimate is 2.6-fold (0.42 log units) above it, and the stated range ends above it.
By their numbers in this assay, from the lowest: compounds 4, 2, 3 and 1 (each within the scatter of the next, the first and the last beyond it).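

In this assay fluoro in place of hydrogen on an aromatic carbon, turning 2-fluorophenyl into 2,4-difluorophenyl, gives a 3.7-fold lower number from compound 1 to compound 4 (0.57 log units; beyond the scatter) and so adds a second halogen with a measurable gain. 2,4-Difluorophenyl in place of 4-chlorophenyl gives a 2.8-fold lower number from compound 3 to compound 4 (0.45 log units; beyond the scatter) while in place of 2-bromophenyl it gives a 1.5-fold lower number from compound 2 to compound 4 (0.17 log units; within the scatter) and so bromo is not required for a number in this range. Nothing available here accounts for these steps.
Open, from the compounds shown here alone, is how 4-fluorophenyl alone compares. Also open, going by these compounds, is whether methoxy or an amine on the aromatic ring would hold this level.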